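This account rests on a few compounds, and the source may have more. Where it says the series, first, only, none or still open, it means among the compounds named here.

Measured so far:
compound 1 `COc1cc(Cl)cc(-c2nn(-c3cccc(NC(=O)Nc4ccc(Cl)c(C(F)(F)F)c4)c3)cc2-c2ccncc2)c1`: 98%
compound 2 `COc1cc(Cl)cc(-c2nn(-c3cccc(NC(=O)Nc4cccc(C(F)(F)F)c4)c3)cc2-c2ccncc2)c1`: 100%

For the measured compounds named here, both values come from a functional assay on NCI/ADR-RES cells (Homo sapiens) for inhibition, read by sulforhodamine B assay, with a stated time of 48 h, tested at 0.01 uM (a higher number here means a weaker effect of the compound at the concentration tested, a lower number a stronger effect), where compound 2 holds the higher of the two numbers, yet its only neighbour, compound 1, sits apart by a number 2 percentage points higher from compound 1 to compound 2 (within the scatter), a gap within the scatter. Compound 3 `COc1cc(Cl)cc(-c2nn(-c3cccc(NC(=O)c4cccc(C(F)(F)F)c4)c3)cc2-c2ccncc2)c1` differs from compound 2 by 3-(trifluoromethyl)phenyl in place of (3-(trifluoromethyl)phenyl)amino on a carbonyl carbon. Going by the values given here, no measured step touches the carbonyl carbon; the single step seen so far, hydrogen in place of chloro on an aromatic carbon, changed nothing beyond the scatter. Compound 3 is therefore expected to give 98%, with a range of 88% to 105%. The expected step is a number 2 percentage points lower from compound 2 to compound 3 (within the scatter), none beyond the scatter.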

Compound 3, a percentage reported as activity, at one concentration (the size of the read-out at that concentration, not a potency): 103%
Compound 3: middle estimate off by 5 percentage points, on the low side, and the stated range covers the measured number.
By their numbers in this assay, from the lowest: compounds 1, 2 and 3 (each within the scatter of the next).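

In this assay the swap on the carbonyl carbon of (3-(trifluoromethyl)phenyl)amino for 3-(trifluoromethyl)phenyl removes a nitrogen and a hydrogen-bond donor, yet it gives a number 3 percentage points higher from compound 2 to compound 3 (within the scatter) and so no real change. Set against the chloro-bearing (4-chloro-3-(trifluoromethyl)phenyl)amino group, the same replacement gives a number 5 percentage points higher from compound 1 to compound 3 (within the scatter) and also stays inside the usual variation. No supporting measurement is available to explain this.

From the compounds shown here alone, all three compounds read alike at this single concentration, so it stays open whether any group on this carbonyl carbon can shift the number. A morpholine or a methylamino group there would be one test.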